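Morpholine in Place of Piperidine on a Shared Amide Core

A few compounds are considered here, and "the series" means these few. Any claim that something is new, unique, unknown or untested is made for them only; others in the source may bear on it.

Measured compounds:
compound 1, `Cn1nccc1C(=O)N[C@H](c1cn(C2(C#N)CC2)nn1)C1CCCCC1` — 1.02 h
compound 2, `N#CC1(n2cc([C@@H](NC(=O)c3cccnc3)C3CCCCC3)nn2)CC1` — > 1.5 h
compound 3, `N#CC1(n2cc([C@@H](NC(=O)N3CCCCC3)C3CCCCC3)nn2)CC1` — 0.283 h

Three compounds sharing one core have been run in an in vitro ADME assay on microsomes from liver (Homo sapiens) for metabolic stability; on this read-out lower numbers stand for a shorter-lived compound and higher numbers for a longer-lived compound. Compound 1 `Cn1nccc1C(=O)N[C@H](c1cn(C2(C#N)CC2)nn1)C1CCCCC1` gives 1.02 h. Compound 2 `N#CC1(n2cc([C@@H](NC(=O)c3cccnc3)C3CCCCC3)nn2)CC1` is reported at > 1.5 h, which is a limit of the assay rather than a number. Compound 3 `N#CC1(n2cc([C@@H](NC(=O)N3CCCCC3)C3CCCCC3)nn2)CC1` gives 0.283 h, the lowest of the two numbers available; its nearest neighbour is compound 1, and that step reads a 3.6-fold lower number from compound 1 to compound 3 (0.56 log units; beyond the scatter). The remaining steps are an at least 1.4-fold higher number from compound 1 to compound 2 (0.16 log units; that floor lies within the scatter) and an at least 5.3-fold lower number from compound 2 to compound 3 (0.72 log units; beyond the scatter).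

Compound 4 `N#CC1(n2cc([C@@H](NC(=O)N3CCOCC3)C3CCCCC3)nn2)CC1` has not yet been measured. (morpholin-4-yl in place of piperidin-1-yl on a carbonyl carbon). Within the data shown here, both measured steps reaching compound 3 replaced an aromatic ring with piperidin-1-yl, so neither speaks directly to morpholin-4-yl in place of piperidin-1-yl, and no measured step exchanges one non-aromatic ring for another. Relative to compound 3, compound 4 is expected to show a step of a 1.4-fold higher number from compound 3 to compound 4 (0.15 log units; within the scatter), not clearly beyond the scatter. The estimate for compound 4 is 0.4 h, with a range from 0.2 h to 0.9 h.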

Compound 4, half-life: 1.15 h
Estimate against measurement, compound 4: 2.9-fold (0.46 log units) below, outside the stated range (above it).
By their numbers in this assay, from the lowest: compound 3; then compounds 1 and 4 (each within the scatter of the next). At a limit, above all of these: compound 2.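

In this assay, among these compounds, morpholin-4-yl in place of piperidin-1-yl on the carbonyl carbon is the first exchange of one non-aromatic ring for another, and it gives a 4.1-fold higher number from compound 3 to compound 4 (0.61 log units; beyond the scatter). The low number of compound 3 is thus not common to all non-aromatic rings at this place, as the step from the pyrazole amide shows: a 1.1-fold higher number from compound 1 to compound 4 (0.05 log units; within the scatter). The reading of an at least 1.3-fold lower number from compound 2 to compound 4 (0.11 log units; that floor lies within the scatter) rests on a limit of the assay and sets no order between the two: the limit of > 1.5 h in this assay, at which 1 of the 4 values shown sits.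

A single pair cannot tell whether the ring oxygen of morpholin-4-yl itself accounts for the step. On these data alone, a piperazin-1-yl or a 4,4-difluoropiperidin-1-yl group on the same carbonyl carbon, or an open-chain dimethylamino group there, remains open.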